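The source may hold more compounds than are shown below. What is called first, only, known or untested is meant among the compounds shown, and "the series" means these compounds.

Compound 1 `C=CC1=C(C(=O)O)C(c2ccc(OC)cc2)OC1` gives in a functional assay on QGY7701 cells (Homo sapiens) for cytotoxicity, read by MTT assay, with a stated time of 24 h (on this read-out higher numbers stand for weaker inhibition and lower numbers for stronger inhibition), the value > 100000 nM, which is a limit of the assay rather than a number.
Compound 2 `C=CC1=C(C(=O)NC(C)(C)C)C(c2ccc(OC)cc2)OC1` gives in this assay the value > 100000 nM, again a limit.
Compound 3 `C=CC1=C(C(=O)NC2CCCCC2)C(c2ccc(OC)cc2)OC1` gives in this assay the value > 100000 nM, also a limit.

Compound 3 therefore stands where every measured compound stands, at the limit of > 100000 nM in this assay, at which 3 of the 3 values shown sit. Compound 4 `C=CC1=C(C(=O)NCCCCC)C(c2ccc(OC)cc2)OC1` differs from compound 3 by pentyl in place of cyclohexyl on an amide-type nitrogen. The nearest measured step is a step that the two limits leave unreadable from compound 2 to compound 3, and the steps a step that the two limits leave unreadable from compound 1 to compound 2 and a step that the two limits leave unreadable from compound 1 to compound 3 are equally unreadable because the limit of > 100000 nM in this assay, at which 3 of the 3 values shown sit, covers all three. No size or direction beyond the scatter can thus be expected; the step from compound 3 to compound 4 is expected to be a step that the limit leaves unreadable from compound 3 to compound 4. Compound 4 is estimated at 150000 nM, within 50000 nM to 500000 nM, most likely reported again only as a limit.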

Compound 4, half-maximal inhibitory concentration: > 100000 nM
Compound 4: a limit, no number; the forecaster's own chance of this, stated with the estimate: 85%; the middle value lies beyond the limit too.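

Compound 4 joins compounds 1, 2 and 3, so no step among these compounds can be read, and every value in this assay stays a limit: the limit of > 100000 nM in this assay, at which 4 of the 4 values shown sit.

What the compounds shown leave open is how strongly any of them inhibits these cells, since none has yet given a number.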